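A Methyl Removal in Three Sulfonamides and a Fourth

A few compounds are considered here, and "the series" means these few. Any claim that something is new, unique, unknown or untested is made for them only; others in the source may bear on it.

In a functional assay on PC-3 cells (Homo sapiens) for inhibition, read by MTT assay, with a stated time of 48 h (a lower number here means a stronger inhibitor, a higher number a weaker inhibitor), the three measured compounds gave these numbers:
compound 1, `COc1cc(N(Cc2cccc(C)c2)S(=O)(=O)c2ccc(C)cc2)cc(OC)c1OC`, 8580 nM;
compound 2, `COc1cc(N(Cc2ccccc2)S(=O)(=O)c2ccc(C)cc2)cc(OC)c1OC`, 7810 nM;
compound 3, `COc1cc(N(Cc2nc3ccccc3[nH]2)S(=O)(=O)c2ccc(C)cc2)cc(OC)c1OC`, 3340 nM.

Compound 2 differs from compound 1 by hydrogen in place of methyl on an aromatic carbon, and that change made a 1.1-fold lower number from compound 1 to compound 2 (0.04 log units; within the scatter). Compound 3 differs from compound 1 by 1H-benzimidazol-2-yl in place of 3-methylphenyl on a saturated chain carbon bound to a sulfonamide nitrogen, giving a 2.6-fold lower number from compound 1 to compound 3 (0.41 log units; beyond the scatter), and from compound 2 by a 2.3-fold lower number from compound 2 to compound 3 (0.37 log units; beyond the scatter).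

Compound 4, `COc1cc(N(Cc2nc3ccccc3[nH]2)S(=O)(=O)c2ccccc2)cc(OC)c1OC`, is not yet measured. It differs from compound 3 by hydrogen in place of methyl on an aromatic carbon. This is the same kind of change as that from compound 1 to compound 2, but the place is not identical: there the methyl sat meta to a large group, here it sits para to a large group. The core of compound 4 is that of compound 3, which differs from the core of compound 1 as told above.

Compound 4 is expected to show a 1.0-fold higher number from compound 3 to compound 4 (0.02 log units; within the scatter), because the earlier step of a 1.1-fold lower number from compound 1 to compound 2 (0.04 log units; within the scatter) stayed within the scatter. Compound 4 is therefore estimated at 3500 nM, between 1700 nM and 7500 nM.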

Compound 4, half-maximal inhibitory concentration: 25500 nM
The estimate for compound 4 lay 7.3-fold (0.86 log units) below the measured number; the whole stated range lies below it.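

In this assay, taking the methyl off the 4-methylphenyl group of compound 3 gave a 7.6-fold higher number from compound 3 to compound 4 (0.88 log units; beyond the scatter), so the change did not carry over unchanged between the two cores: the same change on two cores in this assay, a 1.1-fold lower number (0.04 log units; within the scatter) from compound 1 to compound 2 and a 7.6-fold higher number (0.88 log units; beyond the scatter) from compound 3 to compound 4, 8.4-fold (0.92 log units) apart, beyond the scatter of two such steps

The two methyls also sit in different places, one on the 3-methylphenyl group of compound 1 and the other on the 4-methylphenyl group of compound 3, so the pair cannot separate the effect of the core from that of the place. With one step on each core, this shows a dependence on context for these compounds only, not a rule for the series.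

The compounds shown leave open how the same methyl removal from the 4-methylphenyl group would read on the core of compound 1. Also open, on these data alone, is how a chlorine atom, a methoxy group or an amine in place of that methyl would read in this assay.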